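Methoxy for bromo on compound 1

The source may report more compounds than this note shows. Statements on the series, on what has been measured and on what is new or still open speak of the compounds shown alone.

- compound 1 `COc1ccc(C2=C(c3ccc(SC)cc3)CC3CCCN3C2=O)cc1Br`: 5000 nM
- compound 2 `CSc1ccc(C2=C(c3ccc(C)c(C)c3)C(=O)N3CCCC3C2)cc1`: 700 nM
- compound 3 `CSc1ccc(C2=C(c3ccc(F)c(C)c3)C(=O)N3CCCC3C2)cc1`: 600 nM

In a functional assay on SW-620 cells (Homo sapiens) for cytotoxicity (on this read-out lower numbers stand for stronger inhibition of growth and higher numbers for weaker inhibition of growth), compound 1 has the highest number of the three measured compounds, so it inhibits growth the least. Compound 4 `COc1ccc(C2=C(c3ccc(SC)cc3)CC3CCCN3C2=O)cc1OC` has not yet been measured. It differs from compound 1 by methoxy in place of bromo on an aromatic carbon, ortho to a methoxy group (methoxy in place of bromo on an aromatic carbon).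

Within the data shown here, no measured step makes this exact exchange. The closest evidence comes from replacing the whole 3-bromo-4-methoxyphenyl group of compound 1: a 7.1-fold lower number from compound 1 to compound 2 (0.85 log units; beyond the scatter) and an 8.3-fold lower number from compound 1 to compound 3 (0.92 log units; beyond the scatter). Both steps lie beyond the scatter. The two replacement groups themselves are not separated, since a 1.2-fold lower number from compound 2 to compound 3 (0.07 log units; within the scatter) lies within the scatter. Those steps remove the bromo, but they also remove the methoxy that compound 4 keeps, so they bear on the change only in part. A lower number in this assay is therefore expected, though by a smaller step than those two, and a result within the scatter remains possible. The expected change is a 2.0-fold lower number from compound 1 to compound 4 (0.30 log units; within the scatter). For compound 4 the estimated value is 2500 nM, with an expected range of 700 nM to 8000 nM.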

Compound 4, concentration for 50% growth inhibition: 3000 nM
Estimate against measurement, compound 4: 1.2-fold (0.08 log units) below, within the range that was stated.
By their numbers in this assay, from the lowest: compounds 3 and 2 (each within the scatter of the next); then compounds 4 and 1 (each within the scatter of the next).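

At the aromatic carbon ortho to a methoxy group, methoxy in place of bromo gives a 1.7-fold lower number from compound 1 to compound 4 (0.22 log units; within the scatter) in this assay, so this position accepts a group with a hydrogen-bond acceptor without a change beyond the scatter. The earlier steps shown here replaced the whole 3-bromo-4-methoxyphenyl group at once, as in a 7.1-fold lower number from compound 1 to compound 2 (0.85 log units; beyond the scatter), and could not show what the bromo alone contributes; exchanging this one group does not by itself produce a step beyond the scatter. No measurement at hand offers an explanation for this result.

The compounds shown leave open whether hydrogen, an amine or a hydroxy group on this carbon would move the number beyond the scatter, as only bromo and methoxy appear there with the rest of the structure unchanged. They also leave open what the methoxy retained in compound 1 and compound 4 contributes on its own, as every step that removes it also removes the bromo and replaces the whole aromatic group.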